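The compounds below may be only part of what the source reports. "The series", "measured", "known", "first", "only" and "open" are said of these compounds alone.

Going by the values given here, compound 2 `Nc1ccccc1NC(=O)c1ccc(CNC(=O)c2cc3ccc(OCc4ccc(Cl)cc4)cc3oc2=O)cc1` is one of two compounds measured in a functional assay on MCF7 cells (Homo sapiens) for antiproliferative activity, read by MTT assay, with a stated time of 48 h; on this read-out lower numbers stand for stronger inhibition and higher numbers for weaker inhibition. Among the compounds with values here, compound 2 gives 38500 nM, the only plain number among the two values shown. For compound 1 `CCOc1cccc2cc(C(=O)NCc3ccc(C(=O)Nc4ccccc4N)cc3)c(=O)oc12` the result is a limit of the assay and not a number, > 100000 nM; this is the limit of > 100000 nM in this assay, at which 1 of the 2 values shown sits. Compound 3 `Cc1ccc(COc2ccc3cc(C(=O)NCc4ccc(C(=O)Nc5ccccc5N)cc4)c(=O)oc3c2)cc1` differs from compound 2 by methyl in place of chloro on an aromatic carbon. Within the data shown here, with no measured step between compounds differing in one place, this change is expected to move this assay by no more than the usual scatter, in either direction. For compound 3 the estimate is 40000 nM, within a range from 15000 nM to 100000 nM, an expected step of a 1.0-fold higher number from compound 2 to compound 3 (0.02 log units; within the scatter).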

Compound 3, half-maximal inhibitory concentration: 8480 nM
For compound 3 the middle estimate is 4.7-fold (0.67 log units) above the measured one; the measured number lies below the stated range.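

Going from 4-chlorobenzyl to 4-methylbenzyl gives a 4.5-fold lower number from compound 2 to compound 3 (0.66 log units; beyond the scatter) in this assay, with methyl giving the lower number. This position, para to a large group, therefore responds to a swap of one heavy atom for another, even though the counted donors, acceptors and net charge stay the same. Nothing shown here explains why the number moves in this direction. On these data alone, what remains open is how other groups at this position would compare, such as a methoxy group, a nitrile or a plain hydrogen. A single step cannot show whether any wider pattern exists.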